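Pyrrolidine for Methylpiperazine on a Chloropyrimidine Series

The source may report more compounds than this note shows. Statements on the series, on what has been measured and on what is new or still open speak of the compounds shown alone.

Measured so far:
compound 1 `CCC(=O)Nc1cccc(Oc2nc(Nc3ccc(N4CCN(C)CC4)cc3)ncc2Cl)c1` — 82.6%
compound 2 `CCC(=O)Nc1cccc(Oc2nc(Nc3ccc(N4CCN(C)CC4)cc3Cl)ncc2Cl)c1` — 69.1%

Of the compounds shown here, two have been measured in an assay on isolated protein for inhibition of NUAK family SNF1-like kinase 2 (Homo sapiens), read by ADP-Glo, with a stated time of 60 min, tested at 10 uM, in the presence of a further agent that is not named here; on this read-out lower numbers stand for less inhibition and higher numbers for more inhibition at the one concentration tested (going by the name of the read-out). Compound 1 gives 82.6%, and compound 2 gives 69.1%. They differ only by a chloro in place of hydrogen on an aromatic carbon, and that step is a number 13.5 percentage points lower from compound 1 to compound 2 (beyond the scatter). Compound 1 therefore stands highest of the two numbers, with compound 2 the nearest to it, separated by more than the usual scatter.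

Compound 3 `CCC(=O)Nc1cccc(Oc2nc(Nc3ccc(N4CCCC4)cc3)ncc2Cl)c1` is the next compound to be measured. It differs from compound 1 in one place: pyrrolidin-1-yl in place of 4-methylpiperazin-1-yl on an aromatic carbon. Within the data shown here, the one measured step concerns a different kind of change at a different place, so nothing measured bears directly on this exchange. Among the measured compounds shown here, with no step on the amine ring to draw on, a modest downward movement or no movement beyond the scatter seems the most likely outcome, with compound 1 as the reference. The step from compound 1 to compound 3 is expected to be a number 12.6 percentage points lower from compound 1 to compound 3 (beyond the scatter). Compound 3 is estimated at 70%, within a range from 50% to 88%.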

Compound 3, a percentage reported as inhibition, at one concentration (the size of the read-out at that concentration, not a potency): "not active" (no number reported)
Nothing numeric was reported for compound 3; the estimate stays without a comparison.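

In this assay, among these compounds, compound 3 is reported as "not active" without a number, so no step from compound 1 to compound 3 can be read. Nothing measured here accounts for this result. The compounds shown leave open how large a change in inhibition pyrrolidin-1-yl in place of 4-methylpiperazin-1-yl brings.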